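The source may hold more compounds than are shown below. What is called first, only, known or untested is meant among the compounds shown, and "the series" means these compounds.

Measured compounds and their values in a functional assay on a cell-free system (Platelet, plasma, Homo sapiens) for inhibition, with stated times of 1 min and 3 min; on this read-out lower numbers stand for stronger inhibition and higher numbers for weaker inhibition:
compound 1 `CCCSc1nc(NC2CCCCC2)c2ncn([C@@H]3O[C@H](CO)[C@@H](O)[C@H]3O)c2n1` gives 151000 nM;
compound 2 `CCCSc1nc(NCc2ccccc2)c2ncn([C@@H]3O[C@H](CO)[C@@H](O)[C@H]3O)c2n1` gives 216000 nM;
compound 3 `CCSc1nc(NCc2ccccc2)c2ncn([C@@H]3O[C@H](CO)[C@@H](O)[C@H]3O)c2n1` gives 176000 nM.

All three compounds share a core and differ in two places. Compound 3 differs from compound 2 by hydrogen in place of methyl on a saturated chain carbon, two bonds along the chain from a sulfur, and this gives a 1.2-fold lower number from compound 2 to compound 3 (0.09 log units; within the scatter). Compound 1 differs from compound 2 by cyclohexyl in place of benzyl on a nitrogen on an aromatic ring, and this gives a 1.4-fold lower number from compound 2 to compound 1 (0.16 log units; within the scatter). Compound 4 `CCSc1nc(NC2CCCCC2)c2ncn([C@@H]3O[C@H](CO)[C@@H](O)[C@H]3O)c2n1` is not yet measured; it differs from compound 3 by cyclohexyl in place of benzyl on a nitrogen on an aromatic ring, the same change as that from compound 2 to compound 1, made on the core of compound 3 instead.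

Because the earlier step of a 1.4-fold lower number from compound 2 to compound 1 (0.16 log units; within the scatter) stayed within the scatter, compound 4 is expected to give a number close to that of compound 3, with an estimated step of a 1.4-fold lower number from compound 3 to compound 4 (0.13 log units; within the scatter). Compound 4 is therefore estimated at 130000 nM, with a range from 60000 nM to 280000 nM.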

Compound 4, half-maximal inhibitory concentration: 104000 nM
For compound 4 the middle estimate is 1.3-fold (0.10 log units) above the measured one; measured number inside the range.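

In this assay, cyclohexyl in place of benzyl on a nitrogen on an aromatic ring gives a 1.7-fold lower number from compound 3 to compound 4 (0.23 log units; within the scatter), and this agrees with the same change on the other core: the same change on two cores in this assay, a 1.4-fold lower number (0.16 log units; within the scatter) from compound 2 to compound 1 and a 1.7-fold lower number (0.23 log units; within the scatter) from compound 3 to compound 4, 1.2-fold (0.07 log units) apart, within the scatter of two such steps. Hydrogen in place of methyl on a saturated chain carbon, two bonds along the chain from a sulfur, gives a 1.5-fold lower number from compound 1 to compound 4 (0.16 log units; within the scatter), and this also agrees with its earlier counterpart: the same change on two cores in this assay, a 1.2-fold lower number (0.09 log units; within the scatter) from compound 2 to compound 3 and a 1.5-fold lower number (0.16 log units; within the scatter) from compound 1 to compound 4, 1.2-fold (0.07 log units) apart, within the scatter of two such steps. For the compounds shown here, since all four steps lie within the scatter, the two cores show only that neither change moved the number measurably on either core, not that a real effect carries from one core to another.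

The compounds shown leave open whether a longer chain on the sulfur, or an amine or a carboxylic acid in place of cyclohexyl on the nitrogen, would give a step beyond the scatter. They also leave open whether such a step would hold on both cores.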